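The source may report more compounds than this note shows. Statements on the series, on what has been measured and on what is new or still open speak of the compounds shown alone.

In a functional assay on HepG2 cells (Homo sapiens) for inhibition, read by MTT assay, with a stated time of 48 h (on this read-out lower numbers stand for stronger inhibition and higher numbers for weaker inhibition), compound 1 `COc1cc(-c2nnc(SC)n2-c2ccc(N(C)C)cc2)cc(OC)c1OC` gives > 60000 nM as a limit of the assay and not a number. Compound 2 `COc1ccc(CSc2nnc(-c3cc(OC)c(OC)c(OC)c3)n2-c2ccc(N(C)C)cc2)cc1` gives > 60000 nM as a limit too. Going by the values given here, compound 3 `COc1ccc(C(=O)CSc2nnc(-c3cc(OC)c(OC)c(OC)c3)n2-c2ccc(N(C)C)cc2)cc1` gives 18800 nM as the only true number of the three. Compound 4 `COc1ccc(NC(=O)CSc2nnc(-c3cc(OC)c(OC)c(OC)c3)n2-c2ccc(N(C)C)cc2)cc1` carries (4-methoxyphenyl)amino in place of 4-methoxyphenyl on a carbonyl carbon in the same place, so that (4-methoxyphenyl)carbonyl becomes (4-methoxyphenyl)carbamoyl. The steps of an at least 3.1-fold lower number from compound 1 to compound 3 (0.50 log units; beyond the scatter) and an at least 3.1-fold lower number from compound 2 to compound 3 (0.50 log units; beyond the scatter) bear on this only indirectly: both lead to the carbonyl group, which compound 4 keeps, and neither tests a change on that carbonyl carbon. In this assay no shift beyond the scatter is therefore expected, and the estimated change is a 1.3-fold lower number from compound 3 to compound 4 (0.10 log units; within the scatter) in either direction. For compound 4 the estimate is 15000 nM with an expected range from 5000 nM to 45000 nM in this assay.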

Compound 4, half-maximal inhibitory concentration: > 60000 nM
Compound 4: no number, only a limit; the forecaster's own chance of this, stated with the estimate: 15%; middle value at least 4.0-fold (0.60 log units) from the limit.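

In this assay, the group on the carbonyl carbon matters: (4-methoxyphenyl)amino in place of 4-methoxyphenyl gives an at least 3.1-fold higher number from compound 3 to compound 4 (0.50 log units; beyond the scatter), and the value of compound 4 is a limit of the assay, not a number. The carbonyl alone therefore does not secure a measurable value, since compound 4 keeps it. The steps to compound 4 from compound 1 and from compound 2 cannot be read because both ends of each are limits: the limit of > 60000 nM in this assay, at which 3 of the 4 values shown sit.

From the compounds shown here alone, how far the true value of compound 4 lies beyond its limit stays open. So does whether a carboxylic acid or a dimethylamino group on that carbonyl carbon would give a number.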